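Fluoro to methyl swap on the aryl-substituted pyrrolidine series

The source may hold more compounds than are shown below. What is called first, only, known or untested is meant among the compounds shown, and "the series" means these compounds.

Measured compounds:
Compound 1, `OC[C@]1(c2ccc(F)cc2)NC[C@H](O)[C@H]1O`, in an assay on isolated protein for inhibition of lysosomal alpha-glucosidase (Homo sapiens), tested at 1000 uM; on this read-out lower numbers stand for less inhibition and higher numbers for more inhibition at the one concentration tested (going by the name of the read-out): 8.3%
Compound 2, `OC[C@@]1(c2cccc(F)c2)NC[C@@H](O)[C@@H]1O`, in this assay: 10.3%

The values of compound 1 and compound 2 lie within the usual scatter of each other, so no order between the two can be read from these values. Among the compounds with values here, no pair of measured compounds differs in a single place, so no measured step is available for this series.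

Compound 3 is `Cc1ccc([C@@]2(CO)NC[C@H](O)[C@H]2O)cc1`. Relative to compound 1 the change is methyl in place of fluoro on an aromatic carbon.

Within the data shown here, with both measured compounds showing only weak inhibition and no measured step to lean on, the step of a number 1.7 percentage points higher from compound 1 to compound 3 (within the scatter) is expected to be small, with no change beyond the scatter in either direction. Compound 3 is therefore estimated at 10%, within a range from 0% to 25%.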

Compound 3, a percentage reported as inhibition, at one concentration (the size of the read-out at that concentration, not a potency): 45.9%
The estimate for compound 3 lay 35.9 percentage points below the measured number; measured number above the stated range.
By their numbers in this assay, from the lowest: compounds 1 and 2 (each within the scatter of the next); then compound 3.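

In this assay, methyl in place of fluoro on an aromatic carbon, para to a group of 9 heavy atoms, gives a number 37.6 percentage points higher from compound 1 to compound 3 (beyond the scatter) on the shared core. Within the data shown here, this is the first measured sign that the read-out responds to a change at this position, and the exchange of one heavy atom for another, with no hydrogen-bond donor or acceptor entering or leaving, is enough to produce it. Nothing available bears on the origin of this step.

From the compounds shown here alone, whether the gain is particular to methyl remains open, since a single step cannot show how ethyl, methoxy, chloro, an amine or a carboxylic acid would read at this place. The read-out comes from one concentration, so the potency of compound 3 also remains undefined.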